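Pyridin-4-yl in place of cyclopropyl on the carbonyl

This account rests on a few compounds, and the source may have more. Where it says the series, first, only, none or still open, it means among the compounds named here.

Compound 1 `Cc1n[nH]c(N)c1-c1ccc(Cl)cc1`: > 100000 nM
Compound 2 `Cc1[nH]nc(N)c1-c1cc(C(F)(F)F)cc(C(F)(F)F)c1`: > 100000 nM
Compound 3 `Cc1nn(C(=O)C2CC2)c(N)c1-c1ccc(Cl)c(Cl)c1`: > 100000 nM

All three measured compounds were run in an assay on Sf9 cells for inhibition of inhibitor of nuclear factor kappa-B kinase subunit epsilon (Homo sapiens), read by ADP-Glo, with a stated time of 60 min; on this read-out lower numbers stand for stronger inhibition and higher numbers for weaker inhibition. For compound 1 the assay reports only a limit, > 100000 nM. For compound 2 it likewise reports only a limit, > 100000 nM. Compound 3 also stands at a limit, > 100000 nM, so that every value shown sits at the same edge of the assay (the limit of > 100000 nM in this assay, at which 3 of the 3 values shown sit). Among the compounds with values here, nothing in these numbers separates one compound from another, and no step between measured compounds can be read off.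

Compound 4 `Cc1nn(C(=O)c2ccncc2)c(N)c1-c1ccc(Cl)c(Cl)c1` has not yet been measured. It differs from compound 3 in one place: pyridin-4-yl in place of cyclopropyl on a carbonyl carbon. Within the data shown here, no measured pair carries this change, so its effect in this assay is unknown. With all three measured compounds at the limit, compound 4 is expected to stay close to that edge, and the step from compound 3 to compound 4 is estimated as a number no higher from compound 3 to compound 4 (the limit leaves the size open). Compound 4 is expected to give about 100000 nM, within 20000 nM to 500000 nM, with a fair chance that only a limit is again reported.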

Compound 4, half-maximal inhibitory concentration: > 100000 nM
Compound 4: no number, only a limit (the forecaster's own chance of this, stated with the estimate: 70%); the middle value lies on the limit itself.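

In this assay compound 4 gives > 100000 nM, which is a limit and not a number. Within the data shown here, compound 3 also stands at a limit, so no step between compound 3 and compound 4 can be read. The compounds shown leave open how pyridin-4-yl and cyclopropyl on the carbonyl compare, and how any compound ranks against another: the limit of > 100000 nM in this assay, at which 4 of the 4 values shown sit.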